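The source may report more compounds than this note shows. Statements on the series, on what has been measured and on what is new or still open speak of the compounds shown alone.

Measured in an ADME assay on L1210/0 cells (Mus musculus) for cytotoxicity, with a stated time of 48 h; on this read-out higher numbers stand for weaker inhibition and lower numbers for stronger inhibition:
- Compound 1 `Nc1nc2c(nc(Br)n2COCCO)c(=O)[nH]1`: > 200000 nM, a limit
- Compound 2 `Nc1nc2c(nc(Cl)n2COCCO)c(=O)[nH]1`: > 200000 nM, a limit

Neither entry is a true number. Compound 2 can be placed only by its limit, and the limit of > 200000 nM in this assay, at which 2 of the 2 values shown sit, shows that compound 1 shares it.

Compound 3 `Nc1nc2c(nc(O)n2COCCO)c(=O)[nH]1` has not yet been measured. It carries hydroxy in place of chloro on an aromatic carbon.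

Going by the values given here, one measured step bears on this change, a swap on the same aromatic carbon: a step that the two limits leave unreadable from compound 1 to compound 2. It therefore offers no size to carry over, and no step beyond the usual scatter is expected in either direction. This expectation rests on compound 2, whose limit is > 200000 nM. The expected step is a number no higher from compound 2 to compound 3 (the limit leaves the size open). For compound 3 the estimated value is 200000 nM, with an expected range from 100000 nM to 400000 nM, and the result will most likely be another limit.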

Compound 3, half-maximal inhibitory concentration: > 200000 nM
Compound 3: no number, only a limit (the forecaster's own chance of this, stated with the estimate: 85%); the middle value sits exactly at the limit.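

Going by these compounds alone, compound 3 also gives only a limit, so no step among compound 1, compound 2 and compound 3 can be read: the limit of > 200000 nM in this assay, at which 3 of the 3 values shown sit. The compounds shown leave open whether bromo, chloro and hydroxy on the same aromatic carbon differ at all in this assay.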